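Aryl swap on the shared core: compound 4 from compound 1

A few compounds are considered here, and "the series" means these few. Any claim that something is new, unique, unknown or untested is made for them only; others in the source may bear on it.

Measured so far in a functional assay on HepG2 cells (Homo sapiens) for inhibition, read by MTT assay, with a stated time of 72 h; a lower number here means a stronger inhibitor, a higher number a weaker inhibitor:
compound 1 `CNC(=O)CCCCCCCn1nc(-c2cnc3[nH]ccc3c2)c2c(N)ncnc21`: 5630 nM
compound 2 `Nc1ncnc2c1c(-c1cnc3[nH]ccc3c1)nn2CCCCCCCCC(=O)NO`: 3050 nM
compound 3 `Nc1ncnc2c1c(-c1cnc3[nH]ccc3c1)nn2CCCCCC(=O)NO`: 12900 nM

Compound 1 has the second highest of the three numbers. Its nearest neighbour is compound 2, reached by a 1.8-fold lower number from compound 1 to compound 2 (0.27 log units; within the scatter), a step within the scatter. Its furthest is compound 3, reached by a 2.3-fold higher number from compound 1 to compound 3 (0.36 log units; beyond the scatter). Between the other two, a 4.2-fold higher number from compound 2 to compound 3 (0.63 log units; beyond the scatter) is the largest step in the set. All three measured steps concern the end of the saturated chain only; the shared core and the aryl group on it are the same in every measured compound.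

Compound 4 `CNC(=O)CCCCCCCn1nc(-c2ccc3oc(N)nc3c2)c2c(N)ncnc21` differs from compound 1 in that aryl group: a group of 10 heavy atoms (7 carbon, 2 nitrogen, 1 oxygen; one five-membered aromatic ring with 2 hetero atoms, one six-membered aromatic ring of carbon only) in place of a group of 9 heavy atoms (7 carbon, 2 nitrogen; one five-membered aromatic ring with 1 hetero atom, one six-membered aromatic ring with 1 hetero atom), on an aromatic carbon

Among the measured compounds shown here, no measured step bears on this change. The chain-end steps say nothing about an exchange of the aryl group, so no direction can be read from them, and any step beyond the scatter is as plausible as none. The estimate for compound 4 is therefore anchored on compound 1 with a wide range: compound 4 is expected to give 6000 nM (range 1500 nM to 25000 nM). This expectation corresponds to a 1.1-fold higher number from compound 1 to compound 4 (0.03 log units; within the scatter).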

Compound 4, half-maximal inhibitory concentration: 3640 nM
Estimate against measurement, compound 4: 1.6-fold (0.22 log units) above; the measured number falls inside the stated range.
By their numbers in this assay, from the lowest: compounds 2, 4 and 1 (each within the scatter of the next); then compound 3.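

In this assay the aryl position on the shared core now has its first reading: with the methylcarbamoyl chain end held fixed, placing 2-amino-1,3-benzoxazol-5-yl on this aromatic carbon gives a 1.5-fold lower number from compound 1 to compound 4 (0.19 log units; within the scatter) and the two aryl groups cannot be told apart in this assay. The position, next to the ring nitrogen, therefore tolerates a six-membered aromatic ring of carbon only with a five-membered aromatic ring with 2 hetero atoms, in place of two rings that each carry a hetero atom, without a step beyond the scatter. No supporting measurement is available to explain why the two readings stay together.

Still open, from the compounds shown here alone, is whether 2-amino-1,3-benzoxazol-5-yl behaves the same way with the hydroxycarbamoyl chain ends of compound 2 and compound 3, where the chain length did shift the readings. Also open, going by these compounds, is how the position responds to a simpler aryl group such as phenyl or 4-aminophenyl, and whether a step beyond the scatter can be reached there at all.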